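This account rests on a few compounds, and the source may have more. Where it says the series, first, only, none or still open, it means among the compounds named here.

Measured so far:
compound 1 `O=C(Nc1cc(-c2ccccc2)nn1-c1ccccc1)c1ccccc1Cl` gives 2500 nM
compound 2 `O=C(Nc1cc(-c2ccccc2)nn1-c1ccccc1)c1cnccn1` gives 200 nM

Among the measured compounds shown here, in an assay on CHO cells with metabotropic glutamate receptor 5 (Homo sapiens) as the target (on this read-out higher numbers stand for an effect only at larger amounts of compound and lower numbers for an effect already at smaller amounts), compound 2 holds the lower of the two numbers; the only measured step is a 13-fold lower number from compound 1 to compound 2 (1.10 log units; beyond the scatter). Compound 3 `Cc1ccccc1C(=O)Nc1cc(-c2ccccc2)nn1-c1ccccc1` differs from compound 2 in one place: 2-methylphenyl in place of pyrazin-2-yl on a carbonyl carbon. For the measured compounds named here, this undoes the one kind of change that step covered, with a carbon-only ring again in place of the pyrazinyl, so a step upward is expected, a 10-fold higher number from compound 2 to compound 3 (1.00 log units; beyond the scatter), because compound 1 sits at 2500 nM. Compound 3 is therefore estimated at 2000 nM, with a range of 600 nM to 6000 nM.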

Compound 3, half-maximal effective concentration: > 10000 nM
Compound 3: a limit, no number; the forecaster's own chance of this, stated with the estimate: 10%; at least 5.0-fold (0.69 log units) between middle value and limit.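

Compound 3 gives only a limit of the assay, not a number: the limit of > 10000 nM in this assay, at which 1 of the 3 values shown sits. Carbon-only rings on this carbonyl carbon are not interchangeable: methyl in place of chloro on an aromatic carbon gives an at least 4.0-fold higher number from compound 1 to compound 3 (0.60 log units; beyond the scatter), so the ring substituent counts as well as the ring itself. The span at this position widens to an at least 50-fold higher number from compound 2 to compound 3 (1.69 log units; beyond the scatter), with pyrazin-2-yl still holding the lowest number.

Open, on these data alone, is whether unsubstituted phenyl or pyridin-2-yl would stand closer to compound 2 or to compound 1. Also open, as far as these compounds go, is how a methoxy or amino group on the ring would read.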